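A Ring Replaces an Open Side Chain

The compounds below may be only part of what the source reports. "The series", "measured", "known", "first", "only" and "open" are said of these compounds alone.

In a physicochemical assay for lipophilicity, read by HPLC, at pH 7.5 (a higher number here means a more lipophilic compound, a lower number a more polar compound), compound 1 `CCOc1ccccc1-c1ccc(-c2nc3cnccc3c(N)c2C#N)cc1` gives 3 and compound 2 `CCOc1ccccc1-c1ccc(-c2nc3cnccc3c(NC(COC)C(N)=O)c2C#N)cc1` gives 2.8, so these two values lie within the usual scatter of each other. Compound 3 `CCOc1ccccc1-c1ccc(-c2nc3cnccc3c(N[C@@H]3CCOC3=O)c2C#N)cc1` is still unmeasured. It differs from compound 2 by 2-oxooxolan-3-yl in place of 1-carbamoyl-2-methoxyethyl on a nitrogen on an aromatic ring, with 2-oxooxolan-3-yl in place of 1-carbamoyl-2-methoxyethyl on a nitrogen on an aromatic ring. For the measured compounds named here, only one measured step bears on this: a number 0.20 log units lower from compound 1 to compound 2 (within the scatter), which brought in the departing group and stayed within the scatter. A change beyond the scatter is therefore not expected, and the estimated move is a number 0.20 log units higher from compound 2 to compound 3 (within the scatter). Compound 3 is estimated at 3, with an expected range of 2.6 to 3.4.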

Compound 3, distribution coefficient: 2.7
Beside the measured number, compound 3's estimate is 0.30 log units above it; low and high end bracket the measured number.
By their numbers in this assay, from the lowest: compounds 3, 2 and 1 (each within the scatter of the next).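

In this assay, putting the 2-oxooxolan-3-yl ring in place of the open 1-carbamoyl-2-methoxyethyl chain gives a number 0.10 log units lower from compound 2 to compound 3 (within the scatter), so this swap, which also leaves one hydrogen-bond donor behind, does not move the reading beyond the scatter. With hydrogen on that nitrogen as the starting point, the ring gives a number 0.30 log units lower from compound 1 to compound 3 (within the scatter), which is also within the scatter. Nothing available here explains these readings. As far as these compounds go, whether a carboxylic acid or an amine on this nitrogen would shift the number beyond the scatter remains open, as does the reading of the mirror-image ring.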